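Methylsulfanyl for methoxy on the cinnamoyl ring: next step

This account rests on a few compounds, and the source may have more. Where it says the series, first, only, none or still open, it means among the compounds named here.

Measured so far:
compound 1 `COc1cc(OC)c(C(=O)/C=C/c2ccccc2SC)c(OC)c1` — 0%
compound 2 `COc1cc(O)c(C(=O)/C=C/c2ccccc2OC)c(OC)c1` — 24%

In a functional assay on PC-3 cells (Homo sapiens), read by fluorescence and BrdU incorporation, with a stated time of 48 h, tested at 25 uM (on this read-out lower numbers stand for a stronger effect and higher numbers for a weaker effect at the one concentration tested), compound 1 gives 0%, the lower of the two numbers. In this assay compound 2 gives 24%, the highest of the two numbers on hand; its nearest neighbour is compound 1, whose number lies lower by a gap that is beyond the scatter. Among the compounds with values here, no single-point step joins compound 1 and compound 2, so nothing more than the two values themselves is to be read from that pair.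

Compound 3 `COc1cc(O)c(C(=O)/C=C/c2ccccc2SC)c(OC)c1` has not been measured in this assay. Relative to compound 2 the change is methylsulfanyl in place of methoxy on an aromatic carbon. The same methylsulfanyl group sits in compound 1, which gives the lower of the two measured numbers; compound 3 keeps the rest of compound 2 unchanged.

Within the data shown here, with no measured step for this exact change, the expectation is a move of modest size toward a lower number, of the order of the scatter or somewhat beyond it, carried by compound 1 at 0%. Compound 3 is expected to give 12% in this assay, within 0% to 30%, an estimated step of a number 12 percentage points lower from compound 2 to compound 3 (beyond the scatter).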

Compound 3, a percentage reported as activity, at one concentration (the size of the read-out at that concentration, not a potency): 31%
For compound 3 the middle estimate is 19 percentage points below the measured one, and the stated range ends below it.
By their numbers in this assay, from the lowest: compound 1; then compounds 2 and 3 (each within the scatter of the next).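

In this assay, methylsulfanyl in place of methoxy on an aromatic carbon, ortho to a large group, gives a number 7 percentage points higher from compound 2 to compound 3 (within the scatter) and so does not separate the two groups at this place, at least with the hydroxy group of compound 2 kept in the shared core. The value of compound 1 at 0% therefore cannot be credited to the methylsulfanyl group alone. With methylsulfanyl held fixed, hydrogen in place of methyl on an oxygen on an aromatic ring gives a number 31 percentage points higher from compound 1 to compound 3 (beyond the scatter) as the large step, which places the one clear single-point difference so far at that oxygen, and no measurement on hand gives a reason for either step.

The compounds shown leave open whether the same change at that oxygen gives a step of similar size when methoxy replaces methylsulfanyl on the other ring. Also open, as far as these compounds go, is how a longer chain on that oxygen, such as ethoxy, or an amine in the place of the methylsulfanyl group, would read in this assay against compound 1 and compound 3.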